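This account rests on a few compounds, and the source may have more. Where it says the series, first, only, none or still open, it means among the compounds named here.

Measured compounds:
- Compound 1 `COC(=O)c1scc(-c2ccc(NC(=O)c3ccc4ccccc4c3)cc2)c1OC`: 19500 nM
- Compound 2 `COC(=O)c1scc(-c2ccc(NC(=O)c3ccccn3)cc2)c1OC`: 10300 nM

In a functional assay on HepG2 cells (Homo sapiens) for antiproliferative activity, read by MTT assay, with a stated time of 24 h (a lower number here means a stronger inhibitor, a higher number a weaker inhibitor), compound 2 gives 10300 nM, within the scatter of compound 1 at 19500 nM. Compound 3 `COC(=O)c1scc(-c2ccc(NC(=O)c3cccc(C(F)(F)F)c3)cc2)c1OC` differs from compound 2 as follows: 3-(trifluoromethyl)phenyl in place of pyridin-2-yl on a carbonyl carbon. Among the measured compounds shown here, the one measured step that bears on this change, a 1.9-fold lower number from compound 1 to compound 2 (0.28 log units; within the scatter), exchanged the group on the same carbonyl carbon and stayed within the scatter. Two compounds are thin evidence, but no step beyond the scatter is expected here. The estimate amounts to an expected 1.3-fold higher number from compound 2 to compound 3 (0.10 log units; within the scatter). For compound 3 the estimated value is 13000 nM, with an expected range from 5500 nM to 30000 nM.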

Compound 3, half-maximal inhibitory concentration: 32500 nM
Compound 3: the middle estimate sits 2.5-fold (0.40 log units) below what was measured; measured number outside the range, above it.
By their numbers in this assay, from the lowest: compounds 2, 1 and 3 (each within the scatter of the next, the first and the last beyond it).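

In this assay, exchanging the group on the carbonyl carbon now gives a step beyond the scatter, a 3.2-fold higher number from compound 2 to compound 3 (0.50 log units; beyond the scatter), so this position is not indifferent to the group it carries. The exchange of naphthalen-2-yl for the same 3-(trifluoromethyl)phenyl group stays within the scatter, a 1.7-fold higher number from compound 1 to compound 3 (0.22 log units; within the scatter), so the size of the step depends on the group that leaves. Nothing measured here speaks to what lies behind these steps. The compounds shown leave open how an aliphatic amine or a saturated alkyl chain on this carbonyl carbon would compare with compound 2 in this assay.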